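Adding 4-acetylphenyl to compound 3: working notes

The compounds below may be only part of what the source reports. "The series", "measured", "known", "first", "only" and "open" are said of these compounds alone.

Compound 1 `CC(=O)c1ccc(-c2cccc(NC(=O)CCc3ccc4c(c3)B(O)OC4)c2)cc1`: > 100000 nM (a limit of the assay, not a number)
Compound 2 `CC(=O)c1ccc(-c2cccc(NC(=O)CCc3ccccc3)c2)cc1`: 3200 nM
Compound 3 `O=C(CCc1cccc2c1C(O)OC2)Nc1ccccc1`: 78000 nM
Compound 4 `CC(=O)c1ccc(-c2cccc(NC(=O)CCc3cccc4c3C(O)OC4)c2)cc1`: not yet measured

In a functional assay on SK-OV-3 cells (Homo sapiens) for antiproliferative activity, read by MTT assay, with a stated time of 72 h (on this read-out lower numbers stand for stronger inhibition and higher numbers for weaker inhibition), compound 3 gives 78000 nM, the higher of the two actual numbers. Compound 2 gives 3200 nM, a gap beyond the scatter. The third reading is no number: for compound 1 the record is the limit of > 100000 nM in this assay, at which 1 of the 3 values shown sits.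

The change under study is 4-acetylphenyl in place of hydrogen on an aromatic carbon. In words, 4-acetylphenyl replaces hydrogen on an aromatic carbon.

Among the compounds with values here, no measured step isolates this change. The only one available is an at least 31-fold lower number from compound 1 to compound 2 (1.49 log units; beyond the scatter), a large step made at the group on the saturated chain, with the 4-acetylphenyl present at both ends. It therefore bears only indirectly. Compound 2 at 3200 nM shows that a low number can occur with the 4-acetylphenyl present, but that compound lacks the chain group of compound 4. Compound 1 also carries the 4-acetylphenyl, yet its reading is a limit of the assay.

A modest move toward a lower number is therefore expected, and a limit reading remains possible. The expected change is a 2.6-fold lower number from compound 3 to compound 4 (0.41 log units; beyond the scatter). For compound 4 the estimated value is 30000 nM, with an expected range of 6000 nM to 100000 nM.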

Compound 4, half-maximal inhibitory concentration: 41000 nM
Beside the measured number, compound 4's estimate is 1.4-fold (0.14 log units) below it, within the range that was stated.
By their numbers in this assay, from the lowest: compound 2; then compounds 4 and 3 (each within the scatter of the next). At a limit, above all of these: compound 1.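

In this assay, adding 4-acetylphenyl at this aromatic carbon gives a 1.9-fold lower number from compound 3 to compound 4 (0.28 log units; within the scatter), so on this evidence the change does not separate the two compounds, and the lower reading seen with this group in compound 2 does not carry over to compound 4. The larger difference lies at the group on the saturated chain, two bonds along from the carbonyl carbon, where the step is a 13-fold higher number from compound 2 to compound 4 (1.11 log units; beyond the scatter), so with 4-acetylphenyl present in both compounds, the group at that chain carbon alone separates them beyond the scatter. At the same chain carbon, exchanging the boron-containing group gives an at least 2.4-fold lower number from compound 1 to compound 4 (0.38 log units; beyond the scatter), and the reading for compound 1 is a limit, not a number: the limit of > 100000 nM in this assay, at which 1 of the 4 values shown sits.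

The compounds shown leave open whether any other group at this aromatic carbon, such as an amine or a carboxylic acid, would move the number beyond the scatter. They also leave open whether a longer chain between the carbonyl carbon and the ring group would narrow the gap that compound 4 shows to compound 2.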